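Swapping the charged headgroup in a fibrosis reporter series

The compounds below may be only part of what the source reports. "The series", "measured", "known", "first", "only" and "open" are said of these compounds alone.

Among the compounds with values here, compound 2 `CN(C)c1ccc2c(=O)c(C(=O)Nc3cc(F)cc(F)c3)cn(-c3ccc(OCCCCCCC[N+]45CCN(CC4)CC5)cc3F)c2n1` stands lowest of the two numbers so far in an assay on LX2 cells for inhibition of COL1A1 promoter (Homo sapiens), read by a luciferase reporter, with a stated time of 24 h, tested at 20 uM; a lower number here means a weaker effect, a higher number a stronger effect of the compound at the concentration tested: compound 2 gives 9.02%, while its nearest neighbour, compound 1 `CN(C)c1ccc2c(=O)c(C(=O)Nc3cc(F)cc(F)c3)cn(-c3ccc(OCCCCCCC[N+]45CCN(CC4)CC5)cc3Cl)c2n1`, gives 40.1% in this assay. Within the data shown here, the one measured step between them, a number 31.1 percentage points lower from compound 1 to compound 2 (beyond the scatter), concerns a halogen on an aromatic carbon and says nothing about the charged end of the chain.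

Compound 3 `CN(C)c1ccc2c(=O)c(C(=O)Nc3cc(F)cc(F)c3)cn(-c3ccc(OCCCCCCC[N+]4(C)CCCCC4)cc3F)c2n1` keeps everything else of compound 2 and differs in exactly one place: a group of 7 heavy atoms (6 carbon, 1 nitrogen; one six-membered non-aromatic ring with 1 hetero atom) in place of a group of 8 heavy atoms (6 carbon, 2 nitrogen; 2 six-membered non-aromatic rings with 2 hetero atoms each), on a saturated chain carbon, seven bonds along the chain from an oxygen on an aromatic ring. Among the measured compounds shown here, no measured pair shows a change of this kind, so there is no step to lean on, and the only step in hand bears on a different part of the molecule. The expectation for compound 3 is therefore a step of a number 3 percentage points higher from compound 2 to compound 3 (within the scatter) in this assay, that is, nothing beyond the scatter, with a wide margin either way. Compound 3 is thus estimated to give 12% in this assay, within a range of -8% to 35%.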

Compound 3, a percentage reported as inhibition, at one concentration (the size of the read-out at that concentration, not a potency): "not active" (no number reported)
Compound 3 has no reported number here; the estimate stays without a comparison.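

Within the data shown here, compound 3 is recorded as "not active", with no number, in this assay, which leaves no step from compound 2 to compound 3 to read. No available evidence bears on this result. The compounds shown leave open how exchanging the charged headgroup at the end of the chain changes this read-out by a measurable amount.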